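Capping a Phenol in a Weak Antiproliferative Series

The source may report more compounds than this note shows. Statements on the series, on what has been measured and on what is new or still open speak of the compounds shown alone.

Compound 2 `COc1cc(O)c2c(=O)cc(-c3ccccc3Cl)oc2c1CN1CCCCC1` has the highest, and so weakest, number of the two compounds measured in a functional assay on ECa-109 cells (Homo sapiens) for antiproliferative activity, with a stated time of 72 h (a lower number here means a stronger inhibitor, a higher number a weaker inhibitor), giving 21500 nM, while compound 1 `CCN(C)Cc1c(OC)cc(OC)c(C(=O)/C=C/c2ccccc2Cl)c1O` gives 1400 nM. Compound 3 `COc1cc(OC)c2c(=O)cc(-c3ccccc3Cl)oc2c1CN1CCCCC1` is not yet measured; it differs from compound 2 by methyl in place of hydrogen on an oxygen on an aromatic ring. Among the compounds with values here, no pair of measured compounds shows what this change does, so only a small step, if any beyond the scatter, is expected in this assay: a 1.2-fold higher number from compound 2 to compound 3 (0.07 log units; within the scatter). Compound 3 is therefore expected to give about 25000 nM, somewhere between 8000 nM and 80000 nM.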

Compound 3, half-maximal inhibitory concentration: 23700 nM
Beside the measured number, compound 3's estimate is 1.1-fold (0.02 log units) above it; the range from low to high includes it.
By their numbers in this assay, from the lowest: compound 1; then compounds 2 and 3 (each within the scatter of the next).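

In this assay, going from hydroxy to methoxy on this aromatic ring gives a 1.1-fold higher number from compound 2 to compound 3 (0.04 log units; within the scatter) and so leaves the two compounds indistinguishable. Within the data shown here, this is the first direct reading of this change: at this oxygen, methyl can replace hydrogen with no difference that stands out from the scatter. Nothing measured here offers an explanation for this result.

As far as these compounds go, whether a larger group on the same oxygen, such as a longer chain or one ending in an amine or a carboxylic acid, would also leave the number unmoved remains open.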